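The source may hold more compounds than are shown below. What is called first, only, known or untested is meant among the compounds shown, and "the series" means these compounds.

Measured in a functional assay on HepG2 cells (Homo sapiens) for inhibition, read by MTT assay, with a stated time of 72 h; on this read-out lower numbers stand for stronger inhibition and higher numbers for weaker inhibition:
- compound 1 `CC(C)(C)n1cc2c(n1)C(=O)CC1(CCN(C(=O)c3cc(-c4ccc(F)cc4)nc4ccccc34)CC1)O2`: 2930 nM
- compound 2 `CC(C)(C)n1cc2c(n1)C(=O)CC1(CCN(C(=O)c3cc(-c4ccc(Br)cc4)nc4ccccc34)CC1)O2`: 820 nM
- compound 3 `COc1ccc(-c2cc(C(=O)N3CCC4(CC3)CC(=O)c3nn(C(C)(C)C)cc3O4)c3ccccc3n2)cc1OC`: 1560 nM

Compound 3 cannot be separated from either of the other two: a 1.9-fold lower number from compound 1 to compound 3 (0.27 log units; within the scatter) and a 1.9-fold higher number from compound 2 to compound 3 (0.28 log units; within the scatter) both lie within the scatter. Only a 3.6-fold lower number from compound 1 to compound 2 (0.55 log units; beyond the scatter) goes beyond it, and modestly.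

Compound 4 `CC(C)(C)n1cc2c(n1)C(=O)CC1(CCN(C(=O)c3cc(-c4ccncc4)nc4ccccc34)CC1)O2` carries pyridin-4-yl in place of 3,4-dimethoxyphenyl on an aromatic carbon. All three measured steps vary this same place, but none brings in a ring with a hetero atom, so the read-across is indirect. In this assay no step beyond the scatter is expected, with a slight lean towards a higher number. The expected step is a 1.3-fold higher number from compound 3 to compound 4 (0.11 log units; within the scatter). The estimate for compound 4 is 2000 nM, with an expected range of 750 nM to 5500 nM.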

Compound 4, half-maximal inhibitory concentration: 380 nM
Compound 4: middle estimate off by 5.3-fold (0.72 log units), on the high side; the whole stated range lies above it.
By their numbers in this assay, from the lowest: compound 4; then compounds 2, 3 and 1 (each within the scatter of the next, the first and the last beyond it).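

In this assay, the aromatic carbon next to the ring nitrogen responds to a ring with a hetero atom: pyridin-4-yl gives a 4.1-fold lower number from compound 3 to compound 4 (0.61 log units; beyond the scatter) and a 2.2-fold lower number from compound 2 to compound 4 (0.33 log units; beyond the scatter) and a 7.7-fold lower number from compound 1 to compound 4 (0.89 log units; beyond the scatter), each beyond the scatter. Among the earlier compounds, only compound 1 and compound 2 could be separated, whereas compound 4 stands apart from all three. Nothing available accounts for this shift.

From the compounds shown here alone, whether the ring nitrogen itself or its placement drives the shift stays open. Unsubstituted phenyl, pyridin-3-yl and pyridin-2-yl at this position would separate these readings.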